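The source may hold more compounds than are shown below. What is called first, only, known or untested is meant among the compounds shown, and "the series" means these compounds.

Three compounds in the series have entries in a physicochemical assay for solubility (a higher number here means a more soluble compound, a lower number a less soluble compound), so far. Compound 1 (`CS(=O)(=O)c1ccc(-n2nc(C(F)F)c(C#N)c2-c2ccccc2)cc1`) stands as "not determined" (no result reported) and offers no number to work with. Among the measured compounds shown here, compound 2 (`C[C@@H]1CN(c2c(C#N)c(C(F)F)nn2-c2ccc(S(C)(=O)=O)cc2)[C@H](C)CO1`) gives 50 ug/mL and holds the only number. Compound 3 (`CC1CCCN(c2c(C#N)c(C(F)(F)F)nn2-c2ccc(S(C)(=O)=O)cc2)C1`) stands as "not determined" (no result reported) and so has no place on the scale, with compound 1 the one further entry lacking a number. Compound 4 (`CC1CCCN(c2c(C#N)c(C(F)F)nn2-c2ccc(S(C)(=O)=O)cc2)C1`) awaits measurement. The structural change from compound 3 is hydrogen in place of fluoro on a saturated chain carbon bound to an aromatic carbon and two fluorine atoms and amounts to hydrogen in place of fluoro on a saturated chain carbon bound to an aromatic carbon and two fluorine atoms, or trifluoromethyl to difluoromethyl. For the measured compounds named here, no measured pair shows this change, so no direction can be assigned, and a step in this assay no larger than the usual scatter is the working expectation. With compound 2 at 50 ug/mL as the sole anchor, the range is kept wide. Compound 4 is estimated at 30 ug/mL with an expected range of 10 ug/mL to 90 ug/mL in this measurement.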

Compound 4, solubility: 50 ug/mL
For compound 4 the middle estimate is 1.7-fold (0.22 log units) below the measured one; measured number inside the range.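

In this assay, a group of 7 heavy atoms with one six-membered non-aromatic ring with 1 hetero atom, in place of a group of 8 heavy atoms with one six-membered non-aromatic ring with 2 hetero atoms, on an aromatic carbon, gives no change at the digits printed from compound 2 to compound 4 (within the scatter). Among the compounds shown here, this is the only comparison the series yet allows, and at this aromatic carbon it separates the two rings by nothing beyond the scatter. Steps involving compound 1 or compound 3, including trifluoromethyl to difluoromethyl, cannot be read, and no supporting data bear on the result.

Still open, as far as these compounds go, is how trifluoromethyl and difluoromethyl compare on the shared core. The compounds shown also leave open how an open-chain amine or a carboxylic acid on that aromatic carbon would read in this assay.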